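Chloro for Trifluoromethyl on the Shared Core

The compounds below may be only part of what the source reports. "The series", "measured", "known", "first", "only" and "open" are said of these compounds alone.

Compound 1, `O=C(Nc1ccc(-n2ncc3c(C(F)(F)F)cccc32)cc1)Nc1ccc(Cl)c(C(F)(F)F)c1`, gives 1600 nM in a functional assay on NCI-H460 cells (Homo sapiens) for cytotoxicity, read by MTT assay, with a stated time of 72 h; on this read-out lower numbers stand for stronger inhibition and higher numbers for weaker inhibition.
Compound 2, `O=C(Nc1ccc(-n2ncc3c(C(F)(F)F)cccc32)cc1)Nc1ccc(C(F)(F)F)cc1`, gives 800 nM in this assay.

Compound 2 and compound 1 lie within the scatter of each other: the step of a 2.0-fold lower number from compound 1 to compound 2 (0.30 log units; within the scatter) does not separate them. Compound 3, `O=C(Nc1ccc(-n2ncc3c(Cl)cccc32)cc1)Nc1ccc(C(F)(F)F)cc1`, differs from compound 2 by chloro in place of trifluoromethyl on an aromatic carbon. Among the compounds with values here, the one measured step concerns the other aryl ring, not the shared core, so no measured step bears directly on this change. Compound 3 is therefore expected to show no step beyond the scatter, no change at the digits printed from compound 2 to compound 3 (within the scatter). Compound 3 is estimated at 800 nM in this assay, with a range from 300 nM to 2500 nM.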

Compound 3, half-maximal inhibitory concentration: 6800 nM
Estimate against measurement, compound 3: 8.5-fold (0.93 log units) below, and the stated range ends below it.
By their numbers in this assay, from the lowest: compounds 2 and 1 (each within the scatter of the next); then compound 3.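

In this assay, within the data shown here, the exchange of trifluoromethyl for chloro on this aromatic carbon of the shared core gives an 8.5-fold higher number from compound 2 to compound 3 (0.93 log units; beyond the scatter) and is the first step here beyond the scatter, so this position responds where the earlier change on the other aryl ring did not separate its compounds. The change goes towards weaker inhibition. No measurement shown here accounts for the shift.

On these data alone, whether the step would hold with the 4-chloro-3-(trifluoromethyl)phenyl group on the urea side remains open. So does where a methyl, a methoxy or an amine on this carbon would stand.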